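This account rests on a few compounds, and the source may have more. Where it says the series, first, only, none or still open, it means among the compounds named here.

In a functional assay on HCT-116 cells (Homo sapiens) for inhibition, read by MTT assay, with a stated time of 96 h (on this read-out higher numbers stand for weaker inhibition of growth and lower numbers for stronger inhibition of growth), compound 3 `O=C(NCCCCCCS)c1cc(-c2cnccn2)n[nH]1` gives > 50000 nM, which is a limit of the assay and not a number. Compound 1 `Cc1cc(C(=O)NCCCCCCS)[nH]n1` gives > 50000 nM, again only a limit. Compound 2 `O=C(NCCCCCCS)c1cc(C2CCCCC2)n[nH]1` gives > 50000 nM, also a limit. The whole of the evidence so far is the limit of > 50000 nM in this assay, at which 3 of the 3 values shown sit, so compound 3 cannot be ranked against the other two.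

Compound 4 `O=C(NCCCCCCS)c1ccn[nH]1` carries hydrogen in place of pyrazin-2-yl on an aromatic carbon. Within the data shown here, three measured steps bear on this change, since each exchanges the group on that same aromatic carbon. Among the measured compounds shown here, the first is a step that the two limits leave unreadable from compound 1 to compound 2. The second is a step that the two limits leave unreadable from compound 1 to compound 3. The third is a step that the two limits leave unreadable from compound 2 to compound 3. None of them has a readable size, yet methyl, cyclohexyl and pyrazin-2-yl all end at the same limit. With a step that the two limits leave unreadable from compound 1 to compound 3 as the closest guide, the expected step is a number no higher from compound 3 to compound 4 (the limit leaves the size open), and limits alone support no direction for it. In this assay the most likely result for compound 4 is expected to be another limit rather than a number. Compound 4 is estimated at 50000 nM, with an expected range from 20000 nM to 100000 nM.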

Compound 4, concentration for 50% growth inhibition: > 50000 nM
Compound 4: no number, only a limit (the forecaster's own chance of this, stated with the estimate: 85%); the middle value lies on the limit itself.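

In this assay compound 4 gives > 50000 nM, which is a limit and not a number. Among these compounds, no step from compound 1, compound 2 or compound 3 to compound 4 can be read: the limit of > 50000 nM in this assay, at which 4 of the 4 values shown sit. The compounds shown leave open whether any group on that aromatic carbon alters growth inhibition in this assay.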